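Substituting the sulfonamide nitrogen of compound 2

A few compounds are considered here, and "the series" means these few. Any claim that something is new, unique, unknown or untested is made for them only; others in the source may bear on it.

Measured in an ADME assay on NIH3T3 cells (Mus musculus) for cytotoxicity, read by MTT assay, with a stated time of 48 h; on this read-out higher numbers stand for lower toxicity in this test and lower numbers for higher toxicity in this test:
Compound 1 `COc1ccc(/C=C/C(=O)c2ccc(OC)c(S(N)(=O)=O)c2)cc1`: 96000 nM
Compound 2 `COc1ccc(C(=O)/C=C/c2cc(OC)c(OC)c(OC)c2)cc1S(N)(=O)=O`: 2400 nM

Of these two compounds, compound 2 stands lowest in this assay, and its gap to compound 1 lies beyond the scatter. Compound 3 `COc1ccc(C(=O)/C=C/c2cc(OC)c(OC)c(OC)c2)cc1S(=O)(=O)Nc1c(N)nc(SC)[nH]c1=O` is the next case, still to be measured. It keeps the core of compound 2 and changes in one place: a group of 10 heavy atoms (5 carbon, 3 nitrogen, 1 oxygen, 1 sulfur; one six-membered aromatic ring with 2 hetero atoms) in place of a hydrogen atom, on a sulfonamide nitrogen. In words, a group with one six-membered aromatic ring with 2 hetero atoms comes in place of a hydrogen atom, on a sulfonamide nitrogen.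

Going by the values given here, no two measured compounds differ in one place only, so no measured step calibrates this change. Among the compounds with values here, the two values show only that numbers in this assay can lie far apart. With compound 2 at 2400 nM, the lower of the two numbers, a modest move towards a higher number is expected rather than a further drop. The estimate is a 2.5-fold higher number from compound 2 to compound 3 (0.40 log units; beyond the scatter), a step only slightly beyond the scatter and known with little certainty. For compound 3 the expected value is 6000 nM, with an estimated range of 1200 nM to 30000 nM.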

Compound 3, concentration lethal to 50% of the cells: 2100 nM
Beside the measured number, compound 3's estimate is 2.9-fold (0.46 log units) above it; the range from low to high includes it.
By their numbers in this assay, from the lowest: compounds 3 and 2 (each within the scatter of the next); then compound 1.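

In this assay, the sulfonamide nitrogen now has its first measured single-place step: a group with one six-membered aromatic ring with 2 hetero atoms in place of a hydrogen atom gives a 1.1-fold lower number from compound 2 to compound 3 (0.06 log units; within the scatter). On this read-out, the substituted and unsubstituted sulfonamides therefore cannot be told apart, even though the entering group is a sizeable one bearing hydrogen-bond donors and acceptors, something compounds 1 and 2, which differ elsewhere, could not show. No supporting data bear on this result.

A single substituent on this nitrogen leaves open whether the outcome holds for other groups in the same place, such as a methyl group, an acetyl group or a chain ending in a carboxylic acid, and whether the methylthio group, the amino group or the ring itself matters to the read-out. Also open, as far as these compounds go, is whether the same change on the core of compound 1 would stay within the scatter, as it does here on the core of compound 2.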